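Chloro Added to an Analogue That Shows No Activity

The source may hold more compounds than are shown below. What is called first, only, known or untested is meant among the compounds shown, and "the series" means these compounds.

Compound 2 `N#CC1=C(N)Oc2c(N)cc3nc4ccccc4nc3c2C12C(=O)N(Cc1cnnn1-c1ccc(F)cc1)c1ccccc12` — > 50000 nM
Compound 1 `COc1ccccc1-n1nncc1CN1C(=O)C2(C(C#N)=C(N)Oc3c2c2nc4ccccc4nc2c2ccccc32)c2ccccc21` — > 50000 nM

Of the compounds shown here, two have been tested so far in a functional assay on HepG2 cells (Homo sapiens) for antiproliferative activity, read by MTT assay, with a stated time of 48 h; a higher number here means a weaker inhibitor, a lower number a stronger inhibitor. Compound 1 gives > 50000 nM, and that figure is a limit of the assay, not a measured number. Compound 2 gives > 50000 nM, again a limit rather than a number. Both values therefore rest at the same boundary: the limit of > 50000 nM in this assay, at which 2 of the 2 values shown sit. For the measured compounds named here, from such figures no difference between the two compounds can be read, so no step between measured compounds is available, and compound 2 stands simply at the edge of what the assay can report.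

Compound 3 `N#CC1=C(N)Oc2c(N)cc3nc4ccccc4nc3c2C12C(=O)N(Cc1cnnn1-c1ccc(F)c(Cl)c1)c1ccccc12` is the next compound to be measured. It differs from compound 2 in one place: chloro in place of hydrogen on an aromatic carbon. From what is known here, a change of this size gives no ground to expect a compound that now inhibits cell growth where its neighbour did not. The step is expected to be a number no higher from compound 2 to compound 3 (the limit leaves the size open), nothing beyond the usual scatter. For compound 3 the estimated value is 50000 nM, within 20000 nM to 100000 nM, and the assay will most likely once more report only a limit.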

Compound 3, half-maximal inhibitory concentration: > 50000 nM
Compound 3 was reported as a limit; the forecaster's own chance of this, stated with the estimate: 85%; the middle value lies on the limit itself.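

Compound 3 again stops at a limit rather than a number, so no step from compound 2 to compound 3 can be read: the limit of > 50000 nM in this assay, at which 3 of the 3 values shown sit.

The compounds shown leave open whether chloro in place of hydrogen on this ring changes growth inhibition at all, and which structure, if any, would give a true number instead of a limit.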